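The compounds below may be only part of what the source reports. "The series", "measured", "known", "first", "only" and "open" are said of these compounds alone.

Compound 1, `Cc1ccc2[nH]c(=O)c(-c3nc4ccccc4[nH]3)cc2c1`, gives in a functional assay on HepG2 cells (Homo sapiens) for cytotoxicity, read by MTT assay, with a stated time of 48 h (a higher number here means a weaker inhibitor, a lower number a stronger inhibitor), a value that is a limit of the assay, > 100000 nM.
Compound 2, `COc1ccc2[nH]c(=O)c(-c3nc4ccccc4[nH]3)cc2c1`, gives in this assay likewise a limit, > 100000 nM.
Compound 3, `O=c1[nH]c2ccccc2cc1-c1nc2cc([N+](=O)[O-])ccc2[nH]1`, gives in this assay again a limit, > 100000 nM.

Compound 1 therefore stands at the top of what this assay can report, and it is not alone there: every measured value sits at the limit of > 100000 nM in this assay, at which 3 of the 3 values shown sit. Within the data shown here, the single step between compounds differing in one place, a step that the two limits leave unreadable from compound 1 to compound 2, is thus unreadable, since both ends are limits.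

Compound 4, `Cc1ccc2[nH]c(=O)c(-c3nc4cc(F)ccc4[nH]3)cc2c1`, is not yet measured. It differs from compound 1 by fluoro in place of hydrogen on an aromatic carbon. Among the measured compounds shown here, no measured step speaks to this change, and the one step that exists, a step that the two limits leave unreadable from compound 1 to compound 2, gives no size at all. With every neighbour of compound 4 sitting at the limit, there is no reason in these data to expect a readable number. Compound 4 is therefore expected to give a step that the limit leaves unreadable from compound 1 to compound 4, that is, none beyond the scatter. The estimate for compound 4 in this assay is 150000 nM, with a range from 50000 nM to 500000 nM, and most likely another limit.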

Compound 4, half-maximal inhibitory concentration: > 100000 nM
Compound 4: only a limit was reported (the forecaster's own chance of this, stated with the estimate: 85%); the middle value is on the limit's open side.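

Compound 1 and compound 4 both stand at a limit of the assay, so no step between them can be read: the limit of > 100000 nM in this assay, at which 4 of the 4 values shown sit.

The compounds shown leave open what size, if any, the change of fluoro in place of hydrogen has in this assay, and whether any change to the shared core gives a readable value there.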